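The compounds below may be only part of what the source reports. "The series", "measured", "known", "first", "only" and "open" are said of these compounds alone.

Of the compounds shown here, three have been measured in a functional assay on HEK293 cells for antagonist activity at Voltage-dependent L-type calcium channel subunit alpha-1D (Rattus norvegicus), read by FLIPR; a lower number here means a stronger inhibitor, a higher number a weaker inhibitor. Compound 2 `C#CCCOC(=O)C1=C(C)NC(C)=C(C(=O)OC)C1c1cccc([N+](=O)[O-])c1` gives 35 nM, the lowest number of the three. Compound 1 `CCOC(=O)C1=C(C)NC(COC)=C(C(=O)OC)C1c1cccc([N+](=O)[O-])c1` gives 96 nM, and compound 3 `CCOC(=O)C1=C(C)NC(C)=C(C(=O)OC=O)C1c1cccc([N+](=O)[O-])c1` gives 13900 nM; both gaps to compound 2 lie beyond the usual scatter, so compound 2 stands as the strongest inhibitor of the set. Compound 4 `COC(=O)C1=C(C)NC(C)=C(C(=O)OCc2ccc(OC)cc2)C1c1cccc([N+](=O)[O-])c1` has not been measured. It differs from compound 2 in one place, (4-methoxyphenyl in place of propargyl on a saturated chain carbon bound to an oxygen next to a carbonyl group). Among the compounds with values here, no measured pair in this set shows what this particular change does, so there is nothing direct to lean on. In this assay the expected step is a 1.7-fold higher number from compound 2 to compound 4 (0.23 log units; within the scatter), small, toward a weaker inhibitor or none beyond the scatter. Compound 4 is estimated at 60 nM, with a range from 15 nM to 250 nM.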

Compound 4, half-maximal inhibitory concentration: 79 nM
Compound 4: the middle estimate sits 1.3-fold (0.12 log units) below what was measured; measured number inside the range.
By their numbers in this assay, from the lowest: compound 2; then compounds 4 and 1 (each within the scatter of the next); then compound 3.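

Putting 4-methoxyphenyl in place of propargyl on a saturated chain carbon bound to an oxygen next to a carbonyl group gives only a modest loss in this assay (a 2.3-fold higher number from compound 2 to compound 4 (0.35 log units; beyond the scatter)). This place therefore takes a six-membered aromatic ring and 8 heavy atoms in place of 3, and the number rises only this far. Nothing measured here explains the rise. Going by these compounds, whether plain phenyl or an amine at this place would match compound 2 stays open, as does how much of the step belongs to the methoxy group rather than to the ring.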